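Acetyl on the ring nitrogen: a second look

The source may report more compounds than this note shows. Statements on the series, on what has been measured and on what is new or still open speak of the compounds shown alone.

Measured compounds:
compound 1 `Nc1cccc2c(-c3cccc(NC(=O)c4ccc5c(c4)OCCO5)c3)ccnc12` gives 860 nM
compound 2 `CC(=O)Nc1cccc2c(-c3cccc(NC(=O)c4ccc5c(c4)OCCO5)c3)ccnc12` gives 570 nM
compound 3 `Cc1ccc(NC(=O)c2ccc(Cl)c(C(F)(F)F)c2)cc1-c1ccnc2c(N)cccc12` gives 3300 nM

In a functional assay on A375P cells (Homo sapiens) for antiproliferative activity, read by MTT assay, with a stated time of 48 h (a higher number here means a weaker inhibitor, a lower number a stronger inhibitor), compound 1 gives 860 nM. The change to compound 2 is acetyl in place of hydrogen on a nitrogen on an aromatic ring, and it made a 1.5-fold lower number from compound 1 to compound 2 (0.18 log units; within the scatter). Compound 3 stands on a different core; in this assay compound 3 gives 3300 nM, and the difference between the two cores is not broken down here. Compound 4 `CC(=O)Nc1cccc2c(-c3cc(NC(=O)c4ccc(Cl)c(C(F)(F)F)c4)ccc3C)ccnc12` has not been measured. Among the compounds with values here, it differs from compound 3 by acetyl in place of hydrogen on a nitrogen on an aromatic ring, the same change as the one from compound 1 to compound 2, at a place described in the same words.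

Because the earlier step of a 1.5-fold lower number from compound 1 to compound 2 (0.18 log units; within the scatter) lay within the scatter, the step from compound 3 to compound 4 is expected to be small as well, estimated at a 1.4-fold lower number from compound 3 to compound 4 (0.14 log units; within the scatter). On that basis compound 4 is expected to give 2400 nM in this assay, with the range 1000 nM to 6000 nM allowed for scatter. This rests on a single earlier pair, so the expectation is loose.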

Compound 4, half-maximal inhibitory concentration: 12200 nM
The estimate for compound 4 lay 5.1-fold (0.71 log units) below the measured number; measured number above the stated range.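

In this assay, putting acetyl in place of hydrogen on the ring nitrogen gave a 3.7-fold higher number from compound 3 to compound 4 (0.57 log units; beyond the scatter), so the change did not carry over unchanged from one core to the other: the same change on two cores in this assay, a 1.5-fold lower number (0.18 log units; within the scatter) from compound 1 to compound 2 and a 3.7-fold higher number (0.57 log units; beyond the scatter) from compound 3 to compound 4, 5.6-fold (0.75 log units) apart, beyond the scatter of two such steps

Compound 4 is thus a weaker inhibitor than compound 3, whereas the same amino to acetamido change on the core of compound 1 produced no step beyond the scatter, and a single pair on one core proved a poor guide to the other. Within the data shown here, with only two pairs in one cell assay, this does not show why the cores part ways, nor how the change would behave on a third core.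

The compounds shown leave open whether a longer chain than acetyl, such as propanoyl, or a plain methyl on the same nitrogen would follow the same split between the two cores. Which part of the two cores carries the split also remains open.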